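Shifting the hydroxy group around a cyclohexyl ring

A few compounds are considered here, and "the series" means these few. Any claim that something is new, unique, unknown or untested is made for them only; others in the source may bear on it.

In a functional assay on PC-3M cells (Homo sapiens) for antiproliferative activity, read by microscopy, with a stated time of 24 h (a higher number here means a weaker inhibitor, a lower number a stronger inhibitor), compound 1 `Cc1c(C)n(Cc2ccccc2)c2ncn(C3CCOCC3)c(=N)c12` gives > 20000 nM as its result, which is a limit of the assay and not a number. Compound 2 `COc1ccc(-c2c(-c3ccc(OC)cc3)n(Cc3ccccc3)c3ncn([C@H]4CC[C@H](O)CC4)c(=N)c23)cc1` gives > 20000 nM as its result, and this too is only a limit. Both compounds therefore sit at the same limit of > 20000 nM in this assay, at which 2 of the 2 values shown sit, and neither has a number of its own. Compound 3 `COc1ccc(-c2c(-c3ccc(OC)cc3)n(Cc3ccccc3)c3ncn([C@@H]4CCCC[C@H]4O)c(=N)c23)cc1` keeps the atoms of compound 2 but joins them differently: it has 2-hydroxycyclohexyl in place of 4-hydroxycyclohexyl on an aromatic nitrogen here. Within the data shown here, no measured pair shows what such a change does. The expected a number no higher from compound 2 to compound 3 (the limit leaves the size open) stays within the usual scatter, in no clear direction, and another limit is quite likely. The estimate for compound 3 is 20000 nM and its value is expected to lie between 8000 nM and 40000 nM.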

Compound 3, half-maximal inhibitory concentration: > 20000 nM
Compound 3 was reported as a limit; the forecaster's own chance of this, stated with the estimate: 70%; the middle value lies on the limit itself.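

Compound 3 also stops at a limit of the assay rather than a number, so no step from compound 2 to compound 3 can be read: the limit of > 20000 nM in this assay, at which 3 of the 3 values shown sit.

Whether 2-hydroxycyclohexyl and 4-hydroxycyclohexyl differ at all in this assay stays open, as does the real potency of any of these compounds.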